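The source may report more compounds than this note shows. Statements on the series, on what has been measured and on what is new or still open speak of the compounds shown alone.

Values measured in an ADME assay on microsomes from liver (Homo sapiens) for metabolic stability, with a stated time of 10 min; on this read-out lower numbers stand for a less stable compound and higher numbers for a more stable compound:

Compound 1 `c1ccc(Sc2nn3cc(-c4cc5ccccc5o4)nc3s2)cc1`: "not determined" (no result reported)
Compound 2 `COc1cc(OCc2cccc(COc3ccccc3)c2)c2cc(-c3cn4nc(OC)sc4n3)oc2c1`: 86%
Compound 3 `COc1nn2cc(-c3cc4c(OC)ccc(OC)c4o3)nc2s1`: 55%

Compound 1 has no number on this read-out, so it offers no starting value. The compound to be tested next is compound 4 `COc1nn2cc(-c3cc4ccccc4o3)nc2s1`. The change from compound 1 is methoxy in place of phenylsulfanyl on an aromatic carbon and amounts to methoxy in place of phenylsulfanyl on an aromatic carbon. Compound 2 and compound 3 both carry that methoxy, and their values lie well apart, with compound 3 at 55% and compound 2 at 86% in this assay. No size or direction can be expected for the step itself, as compound 1 lacks a value to measure it from. Compound 3 is the closest measured structure, differing from compound 4 by further methoxy groups on the core. A result for compound 4 within the usual scatter of compound 3 (55%) is therefore expected, though with wide uncertainty. In this assay compound 4 is estimated at 60%, with an expected range of 35% to 85% around that figure.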

Compound 4, percent of the compound remaining: 80%
Compound 4: middle estimate off by 20 percentage points, on the low side, within the range that was stated.
By their numbers in this assay, from the lowest: compound 3; then compounds 4 and 2 (each within the scatter of the next).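

In this assay, within the data shown here, compound 1 reads "not determined" (no result reported) and compound 4 reads 80% and no step between the two can be read. The compounds shown leave open what methoxy in place of phenylsulfanyl does to stability on this read-out. No measured evidence bears on this result.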